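The compounds below may be only part of what the source reports. "The series", "measured", "known", "first", "only" and "open" are said of these compounds alone.

Compound 1 `Cc1ccccc1Oc1ccc(N2C[C@@H](C(F)(F)F)C[C@H]2CC(=O)O)cc1` gives 330 nM in a functional assay on cells for agonist activity at Free fatty acid receptor 1 (Mus musculus), read by FLIPR and calcium flux, with a stated time of 100 s; on this read-out higher numbers stand for an effect only at larger amounts of compound and lower numbers for an effect already at smaller amounts. Compound 2 `Cc1ccccc1Cc1ccc(N2C[C@@H](C(F)(F)F)C[C@H]2CC(=O)O)cc1` gives 710 nM in this assay.

Among the compounds with values here, of these two numbers, compound 1 has the lower one; its nearest neighbour is compound 2, and the only measured step, a 2.2-fold higher number from compound 1 to compound 2 (0.33 log units; beyond the scatter), concerns the link between the two rings, where a 2-methylbenzyl replaces a 2-methylphenoxy on an aromatic carbon.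

Compound 3 `Cc1cc(OCc2ccccc2)ccc1Oc1ccc(N2C[C@@H](C(F)(F)F)C[C@H]2CC(=O)O)cc1` has not been measured. It differs from compound 1 by benzyloxy in place of hydrogen on an aromatic carbon, the new group sitting meta to a methyl group and para to a large group. Within the data shown here, no measured step in this set adds a group at that place; the step from compound 1 to compound 2 alters the linker and therefore bears on this change only indirectly, showing that the two measured compounds lie close together on this read-out. The size of the step in this assay for compound 3 is thus uncertain, and a change no larger than modest, in either direction, is expected. On that basis compound 3 is estimated at 450 nM, with a range from 130 nM to 1500 nM, an expected step of a 1.4-fold higher number from compound 1 to compound 3 (0.13 log units; within the scatter).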

Compound 3, half-maximal effective concentration: 1500 nM
Compound 3: middle estimate off by 3.3-fold (0.52 log units), on the low side; the range from low to high includes it.
By their numbers in this assay, from the lowest: compound 1; then compound 2; then compound 3.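

Placing benzyloxy in place of hydrogen on an aromatic carbon, meta to a methyl group and para to a large group, gives a 4.5-fold higher number from compound 1 to compound 3 (0.66 log units; beyond the scatter) in this assay, so this place takes a group carrying a six-membered aromatic ring with a modest step towards larger amounts of compound and not with a complete loss of the read-out. Within the data shown here, this is the only measured change at this place, whereas a 2.2-fold higher number from compound 1 to compound 2 (0.33 log units; beyond the scatter) concerns the link between the rings and said nothing about adding a group here; the new step is the larger of the two, and it runs in the same direction. Nothing given here accounts for the size or the direction of this step.

On these data alone, what remains open is whether the step belongs to the whole benzyloxy group or only to part of it, a question that a methoxy group, a hydroxyl group or a phenyl ring at the same place would address. As far as these compounds go, whether benzyloxy would give a similar step on compound 2, with its 2-methylbenzyl, also remains open.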